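Trimethoxyphenyl triazoles: removing the isopropoxy group

The source may report more compounds than this note shows. Statements on the series, on what has been measured and on what is new or still open speak of the compounds shown alone.

Compound 1 `COc1cc(-n2ncnc2-c2ccc(OC(C)C)cc2)cc(OC)c1OC` is the reference point of the series. In a functional assay on MCF7 cells (Homo sapiens) for antiproliferative activity, read by MTT assay, with a stated time of 72 h (a higher number here means a weaker inhibitor, a lower number a stronger inhibitor), compound 1 gives 610 nM, the lowest of the two numbers in hand. Compound 2 `COc1ccc(-n2ncnc2-c2cc(OC)c(OC)c(OC)c2)cc1` gives 7400 nM. Compound 3 `COc1cc(-c2ncnn2-c2ccc(Cl)c(Cl)c2)cc(OC)c1OC` reaches only the assay limit, > 10000 nM, which is the limit of > 10000 nM in this assay, at which 1 of the 3 values shown sits. Going by the values given here, the one measured step, an at least 1.3-fold higher number from compound 2 to compound 3 (0.13 log units; that floor lies within the scatter), concerns the aryl on the aromatic nitrogen and not the position changed here. Compound 4 `COc1cc(-n2ncnc2-c2ccccc2)cc(OC)c1OC` differs from compound 1 by hydrogen in place of isopropoxy on an aromatic carbon. Among the compounds with values here, no measured step touches the isopropoxy position, so the data leave its effect open. A modest weakening is nonetheless expected, and the expected step is a 3.3-fold higher number from compound 1 to compound 4 (0.52 log units; beyond the scatter). Compound 4 is accordingly estimated at 2000 nM, within 600 nM to 7000 nM.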

Compound 4, half-maximal inhibitory concentration: > 10000 nM
Compound 4 ended at the assay's limit; the forecaster's own chance of this, stated with the estimate: 15%; middle value at least 5.0-fold (0.69 log units) from the limit.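

In this assay, hydrogen in place of isopropoxy on this aromatic carbon, para to a large group, gives an at least 16-fold higher number from compound 1 to compound 4 (1.21 log units; beyond the scatter). Going by these compounds alone, the position therefore matters strongly, which the earlier compounds could not show, since their one measured step concerned another site. Compound 4 gives only a limit of the assay and not a number, so the full size of the step stays unknown: the limit of > 10000 nM in this assay, at which 2 of the 4 values shown sit.

On these data alone, whether an ethoxy group, a longer alkoxy chain or an amine at this position would match compound 1 remains open. As far as these compounds go, it is also open whether the ether oxygen or the isopropyl carbons account for the difference.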